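Quinoline ureas: cytotoxicity limits and a dimethylamino analogue

The source may report more compounds than this note shows. Statements on the series, on what has been measured and on what is new or still open speak of the compounds shown alone.

compound 1 `Cc1cc(NC(=O)Nc2ccccc2C(F)(F)F)c2ccccc2n1` — > 25000 nM
compound 2 `COC(=O)c1cccc(NC(=O)Nc2cc(C)nc3ccccc23)c1` — 23000 nM
compound 3 `Cc1cc(NC(=O)Nc2cccc([N+](=O)[O-])c2)c2ccccc2n1` — > 25000 nM

In an ADME assay on HepG2 cells (Homo sapiens) for cytotoxicity, with a stated time of 72 h (a lower number here means that less compound is needed, a higher number that more compound is needed for the effect), compound 1 gives only a limit, > 25000 nM. Compound 2 gives a number, 23000 nM. Compound 3 again gives only a limit, > 25000 nM. Compound 3 therefore stands at the upper edge of what this assay reports, and it shares that position with compound 1, as the limit of > 25000 nM in this assay, at which 2 of the 3 values shown sit, records; compound 2 alone sits at a measured number.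

Among the compounds with values here, the only step between measured compounds that differ in one place is an at least 1.0-fold higher number from compound 2 to compound 3 (0.03 log units; that floor lies within the scatter); it is a floor, and that floor lies within the scatter.

Compound 4 `Cc1cc(NC(=O)Nc2cccc(N(C)C)c2)c2ccccc2n1` is not yet measured in this assay. It differs from compound 3 as follows: dimethylamino in place of nitro on an aromatic carbon

The step that bears on this change is an at least 1.0-fold higher number from compound 2 to compound 3 (0.03 log units; that floor lies within the scatter), a replacement at the same aromatic carbon that moved the value no further than from a number to a limit. Given that, and given that compound 3 itself stands at > 25000 nM, no step beyond the scatter is expected; the estimated step of a number no higher from compound 3 to compound 4 (the limit leaves the size open) is expected to be flat. For compound 4 the expected reading in this assay is 25000 nM, with a range from 12000 nM to 50000 nM, and a limit rather than a number is the more likely outcome.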

Compound 4, half-maximal effective concentration: > 25000 nM
Compound 4: a limit, no number; the forecaster's own chance of this, stated with the estimate: 65%; the middle value lies on the limit itself.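

In this assay, the aromatic carbon meta to a large group now carries a third group, and dimethylamino in place of methoxycarbonyl gives an at least 1.0-fold higher number from compound 2 to compound 4 (0.03 log units; that floor lies within the scatter). The step between the nitro and dimethylamino compounds cannot be read, as both values are limits. The new information is that dimethylamino, which brings carbon where nitro brought oxygen and has no double bond outside aromatic rings, leaves the compound at the same reporting limit as nitro, and compound 2 remains the only compound with a number: the limit of > 25000 nM in this assay, at which 3 of the 4 values shown sit.

As far as these compounds go, compound 2 is the only anchor for size, and none of the readable steps goes beyond the scatter, so how far compound 3 and compound 4 truly differ from each other and from compound 2 stays open. From the compounds shown here alone, whether any group at this aromatic carbon gives a clear move away from the limit also stays open, and a primary amine, a carboxylic acid or a longer chain ending in an amine would be needed there to show it.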